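Trading 3,4-dihydroxyphenyl for 4-hydroxycyclohexyl in compound 2

The compounds below may be only part of what the source reports. "The series", "measured", "known", "first", "only" and "open" are said of these compounds alone.

In a functional assay on HeLa cells (Homo sapiens) for inhibition, read by CCK-8 assay, with a stated time of 48 h (on this read-out higher numbers stand for weaker inhibition and lower numbers for stronger inhibition), compound 1 (`COc1ccc(Oc2ccc([N+](=O)[O-])cc2-c2ccsc2S(=O)(=O)N2CCN(C(=S)Nc3ccc(Cl)cc3)CC2)cc1OC`) gives > 50000 nM as a limit of the assay and not a number. Compound 2 (`O=C(NCCNS(=O)(=O)c1ccc(-c2ccccc2Oc2ccc(O)c(O)c2)s1)Nc1cc(Cl)cc(Cl)c1`) gives > 20000 nM and that too is a limit, so compound 2 stands on this read-out without a measured number. Compound 3 (`O=C(NCCNS(=O)(=O)c1ccc(-c2ccccc2O[C@H]2CC[C@H](O)CC2)s1)Nc1cc(Cl)cc(Cl)c1`) has not yet been measured. The change 4-hydroxycyclohexyl in place of 3,4-dihydroxyphenyl on an oxygen on an aromatic ring puts 4-hydroxycyclohexyl in place of 3,4-dihydroxyphenyl on an oxygen on an aromatic ring and leaves the rest of compound 2 as it is. Among the measured compounds shown here, no measured pair of compounds shows what such a swap does. In this assay no change beyond the usual scatter is therefore expected, in either direction. The expected step that the limit leaves unreadable from compound 2 to compound 3 is small. For compound 3 the estimated value is 30000 nM with an expected range from 12000 nM to 80000 nM and a good chance of only a limit of the assay.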

Compound 3, half-maximal inhibitory concentration: > 20000 nM
Compound 3: no number, only a limit; the forecaster's own chance of this, stated with the estimate: 75%; the middle value lies beyond the limit too.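

In this assay compound 3 gives > 20000 nM, a limit of the assay and not a number. Among the compounds shown here, compound 2 also stands only at a limit, so no step from compound 2 to compound 3 can be read. Going by these compounds, what 4-hydroxycyclohexyl in place of 3,4-dihydroxyphenyl does to inhibition stays open.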